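The compounds below may be only part of what the source reports. "The series", "measured", "known", "first", "only" and "open" are said of these compounds alone.

Working notes on the series.

Compound 1 `CCc1nc(C(F)(F)F)c2n1CCN([C@@H](C(=O)NC)c1ccccc1)[C@H]2CCc1ccc(C(F)(F)F)cc1` is the stronger of the two measured compounds: in a functional assay on CHO cells for antagonist activity at Orexin/Hypocretin receptor type 1 (Homo sapiens), read by FLIPR and calcium flux (on this read-out lower numbers stand for stronger inhibition and higher numbers for weaker inhibition), compound 1 gives 1070 nM, the lowest of the two numbers recorded. Compound 2 `CCOc1nc(CC)n2c1C(CCc1ccc(C(F)(F)F)cc1)N([C@@H](C(=O)NC)c1ccccc1)CC2` differs in the group on the same aromatic carbon of the shared core; in this assay compound 2 gives 3980 nM, a gap to compound 1 that lies beyond the scatter.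

Compound 3 `CCc1nc(SC)c2n1CCN([C@@H](C(=O)NC)c1ccccc1)[C@H]2CCc1ccc(C(F)(F)F)cc1` is the next entry, not yet measured. Relative to compound 1 the change is methylsulfanyl in place of trifluoromethyl on an aromatic carbon. Among the measured compounds shown here, no step between two measured compounds covers this exact exchange, so the expectation rests only on the two numbers above. The step from compound 1 to compound 3 is expected to be a 1.9-fold higher number from compound 1 to compound 3 (0.27 log units; within the scatter), that is, a moderate loss, since compound 2 shows that replacing the trifluoromethyl at this carbon gave 3980 nM. For compound 3 a value of 2000 nM is estimated, with a range from 700 nM to 6000 nM.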

Compound 3, half-maximal inhibitory concentration: 85 nM
Estimate against measurement, compound 3: 24-fold (1.37 log units) above, outside the stated range (below it).
By their numbers in this assay, from the lowest: compound 3; then compound 1; then compound 2.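

In this assay the exchange of trifluoromethyl for methylsulfanyl on this aromatic carbon gives a 13-fold lower number from compound 1 to compound 3 (1.10 log units; beyond the scatter), so a change at this position alone can produce a large step towards stronger inhibition. The only replacement seen before, the ethoxy group of compound 2 at 3980 nM, gave a higher number than compound 1, so the group on this carbon can move the number in either direction. No measured information on the cause of the step is at hand.

The three compounds leave open whether the sulfur atom itself matters, which methoxy or ethylsulfanyl on this carbon could address. They also leave open whether methylsulfanyl gives a similar step when a propyl group stands in place of the ethyl group.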